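A few compounds are considered here, and "the series" means these few. Any claim that something is new, unique, unknown or untested is made for them only; others in the source may bear on it.

Measured in a functional assay on MCF7 cells (Homo sapiens) for antiproliferative activity, read by MTT assay, with a stated time of 48 h; a lower number here means a stronger inhibitor, a higher number a weaker inhibitor:
- Compound 1 `C=C1[C@H](OC(C)=O)[C@@H](OC(C)=O)[C@@H](O)C(C)(C)/C=C/[C@H](C)[C@H](OC(=O)c2ccccc2)[C@@]2(O)C[C@@](C)(O)[C@H](OC(C)=O)[C@@H]2[C@H]1OCC(C)C`: > 100000 nM (a limit)
- Compound 2 `C=C1[C@H](OC(C)=O)[C@@H](OC(C)=O)[C@@H](OC(C)=O)C(C)(C)/C=C/[C@H](C)[C@H](OC(=O)c2ccccc2)[C@@]2(O)C[C@@](C)(O)[C@H](OC(C)=O)[C@@H]2[C@H]1OCC(C)C`: > 100000 nM (a limit)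

Compound 2 gives > 100000 nM, which is a limit and not a number. the limit of > 100000 nM in this assay, at which 2 of the 2 values shown sit, is all that the measurements show so far. Compound 3 `C=C1[C@H](OC(C)=O)[C@@H](OC(=O)c2cccc(C)c2)[C@@H](OC(C)=O)C(C)(C)/C=C/[C@H](C)[C@H](OC(=O)c2ccccc2)[C@@]2(O)C[C@@](C)(O)[C@H](OC(C)=O)[C@@H]2[C@H]1OCC(C)C` differs from compound 2 by 3-methylphenyl in place of methyl on a carbonyl carbon, with 3-methylphenyl in place of methyl on a carbonyl carbon. Among the compounds with values here, the one measured step bearing on this is a step that the two limits leave unreadable from compound 1 to compound 2, so it offers no size to carry over. No step beyond the scatter is therefore expected in this assay, and a limit is again likely. The expected step is a number no higher from compound 2 to compound 3 (the limit leaves the size open). Compound 3 is estimated at 100000 nM, within an expected range of 30000 nM to 200000 nM.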

Compound 3, half-maximal inhibitory concentration: 23400 nM
The estimate for compound 3 lay 4.3-fold (0.63 log units) above the measured number; the whole stated range lies above it.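

In this assay, replacing acetoxy with ((3-methylphenyl)carbonyl)oxy gives an at least 4.2-fold lower number from compound 2 to compound 3 (0.63 log units; beyond the scatter), so this position can yield a readable number. The earlier step, at a different oxygen, cannot be read, so this is the first change shown to move a compound off the limit: the limit of > 100000 nM in this assay, at which 2 of the 3 values shown sit.

Going by these compounds, how large the step really is stays open, as compound 2 carries only a limit. On these data alone, it is also open whether the ring methyl matters, or whether a plain phenyl, a 3-aminophenyl or a longer chain such as butanoyl on this carbonyl carbon would give a similar number.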